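Shortening the hydrazide chain on the biaryl core

The compounds below may be only part of what the source reports. "The series", "measured", "known", "first", "only" and "open" are said of these compounds alone.

For the measured compounds named here, compound 2 `CCCCCCNNC(=O)c1ccc(-c2ccc(CNC(C)=O)cc2)cc1` gives 36 nM in an assay on isolated protein for inhibition of histone deacetylase 8 (Homo sapiens), read by fluorescence, with a stated time of 5 min (a higher number here means a weaker inhibitor, a lower number a stronger inhibitor), the lowest of the three numbers so far. Compound 1 `CCCCCNNC(=O)c1ccc(-c2ccc(CNC(C)=O)cc2)cc1` gives 350 nM in this assay; compound 3 `CCCNNC(=O)c1cnc(NCc2ccccc2)nc1`, on a different core, gives 1000 nM. Going by the values given here, the one single-point step so far, a 9.7-fold lower number from compound 1 to compound 2 (0.99 log units; beyond the scatter), shows that lengthening the chain lowered the number. Compound 4 `CCCNNC(=O)c1ccc(-c2ccc(CNC(C)=O)cc2)cc1` goes the other way: hydrogen in place of propyl on a saturated chain carbon, three bonds along the chain from an amine nitrogen. Among the compounds with values here, only the step from compound 1 to compound 2 bears on it, and that step was modest but beyond the scatter. Within the data shown here, compound 4 is therefore expected to show a 69-fold higher number from compound 2 to compound 4 (1.84 log units; beyond the scatter) in this assay, an estimated 2500 nM with a range from 500 nM to 15000 nM, since the chain is cut further than the single measured step covered.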

Compound 4, half-maximal inhibitory concentration: 700 nM
Compound 4: the middle estimate sits 3.6-fold (0.55 log units) above what was measured; measured number inside the range.
By their numbers in this assay, from the lowest: compound 2; then compounds 1, 4 and 3 (each within the scatter of the next, the first and the last beyond it).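

On the shared core in this assay, cutting hexyl to propyl is a large step (a 19-fold higher number from compound 2 to compound 4 (1.29 log units; beyond the scatter)). Cutting pentyl to propyl leaves no readable change (a 2.0-fold higher number from compound 1 to compound 4 (0.30 log units; within the scatter)), so the effect of chain length is not spread evenly along the chain. Of the three chains on this core, only hexyl stands apart from the others. On these data alone, whether a heptyl or longer chain lowers the number further remains open, as does the effect of an amine at the chain end. No measurement here bears on the reason for this pattern.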